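The source may report more compounds than this note shows. Statements on the series, on what has been measured and on what is new or still open speak of the compounds shown alone.

Measured compounds:
- compound 1, `Nc1ccc(-c2nc3ccccc3s2)c(Br)c1`: in a functional assay on MDA-MB-468 cells (Homo sapiens) for inhibition (a higher number here means a weaker inhibitor, a lower number a stronger inhibitor), compound 1 gives < 0.1 nM, which is a limit of the assay and not a number.
- compound 2, `Cc1ccc2nc(-c3ccc(N)cc3Br)sc2c1`: in this assay compound 2 gives < 0.1 nM, again a limit of the assay.

Among the measured compounds shown here, compound 1 thus stands only at a limit in this assay, and the one further value shown, that of compound 2, is also a limit; the limit of < 0.1 nM in this assay, at which 2 of the 2 values shown sit, covers both entries. For the measured compounds named here, the single recorded step, from compound 1 to compound 2, is a step that the two limits leave unreadable from compound 1 to compound 2, methyl in place of hydrogen on an aromatic carbon, and its size cannot be read from two limits.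

Compound 3, `N#Cc1cc(N)ccc1-c1nc2ccccc2s1`, is not yet measured. It differs from compound 1 by cyano in place of bromo on an aromatic carbon, in words cyano in place of bromo on an aromatic carbon. Going by the values given here, no measured step bears on this change: the only step in hand concerns a methyl elsewhere on the shared core, and it is itself unreadable. Direction and size of the move in this assay therefore cannot be taken from the data, and a step beyond the scatter in either direction remains possible. Compound 3 is estimated at 0.3 nM, with a wide range from 0.05 nM to 5 nM. That estimate means an expected step of an at least 3.0-fold higher number from compound 1 to compound 3 (0.47 log units; beyond the scatter), taken from the limit at which compound 1 sits.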

Compound 3, half-maximal inhibitory concentration: < 0.1 nM
Compound 3 gave a limit, no number (the forecaster's own chance of this, stated with the estimate: 35%); middle value at least 3.0-fold (0.47 log units) from the limit.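

No step can be read from compound 1 to compound 3: both stand only at a limit of the assay, so the change of bromo to cyano gives no size and no direction. The compounds shown leave open how compound 1, compound 2 and compound 3 rank in this assay and whether cyano in place of bromo changes inhibition at all, as every value sits at one limit: the limit of < 0.1 nM in this assay, at which 3 of the 3 values shown sit.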